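This account rests on a few compounds, and the source may have more. Where it says the series, first, only, none or still open, it means among the compounds named here.

Measured so far in a functional assay on HT-29 cells (Homo sapiens) for cytotoxicity, read by MTT assay, with a stated time of 72 h; on this read-out lower numbers stand for stronger inhibition and higher numbers for weaker inhibition:
compound 1 `CN(C)CCn1cnnc1-c1cc(Oc2ccc(NC(=O)N/N=C/c3c(Cl)cccc3Cl)cc2F)ccn1` gives 280 nM;
compound 2 `COc1ccc(OC)c(/C=N/NC(=O)Nc2ccc(Oc3ccnc(-c4nncn4CCN(C)C)c3)c(F)c2)c1` gives 2070 nM;
compound 3 `Cn1ncnc1-c1cc(Oc2ccc(NC(=O)N/N=C/c3ccccc3)cc2F)ccn1` gives 30200 nM.

On these numbers compound 2 stands in the middle: compound 1 sits well below it, compound 3 well above it. Compound 4 `CN(C)CCn1cnnc1-c1cc(Oc2ccc(NC(=O)N/N=C/c3ccc(F)cc3)cc2F)ccn1` has not been measured; it differs from compound 2 by 4-fluorophenyl in place of 2,5-dimethoxyphenyl on a carbon with a double bond to nitrogen. For the measured compounds named here, the one measured step at the same place, a 7.4-fold higher number from compound 1 to compound 2 (0.87 log units; beyond the scatter), shows that swapping the ring on that carbon can move this assay by a modest amount. Going by the values given here, compound 3, which carries a plain phenyl there but also a different group on the shared core, gives the highest number of the three, so no clean step to compound 4 exists. A higher number than compound 2 is therefore expected, of size a 2.9-fold higher number from compound 2 to compound 4 (0.46 log units; beyond the scatter). For compound 4 the estimate is 6000 nM, within 1500 nM to 25000 nM.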

Compound 4, half-maximal inhibitory concentration: 1370 nM
Estimate against measurement, compound 4: 4.4-fold (0.64 log units) above; measured number outside the range, below it.
By their numbers in this assay, from the lowest: compound 1; then compounds 4 and 2 (each within the scatter of the next); then compound 3.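

In this assay, 4-fluorophenyl and 2,5-dimethoxyphenyl on the carbon with a double bond to nitrogen cannot be told apart, with a 1.5-fold lower number from compound 2 to compound 4 (0.18 log units; within the scatter). The 2,6-dichlorophenyl ring of compound 1 stands apart from both, with a 4.9-fold higher number from compound 1 to compound 4 (0.69 log units; beyond the scatter), so that gap is not peculiar to the 2,5-dimethoxyphenyl ring. Nothing shown here explains this difference. As far as these compounds go, whether a ring carrying an amine or a carboxylic acid at this place would match compound 1 stays open. Steps to compound 3 cannot be read, as it differs from the others in more than one place.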